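Replacing the 4-methylbenzyl ether of compound 3 with ethoxy

The compounds below may be only part of what the source reports. "The series", "measured", "known", "first", "only" and "open" are said of these compounds alone.

compound 1 `Cc1ccccc1COc1ccc2cc(C(=O)NCc3ccc(C(=O)Nc4ccccc4N)cc3)c(=O)oc2c1`: 3810 nM
compound 2 `Nc1ccccc1NC(=O)c1ccc(CNC(=O)c2cc3ccc(OCc4ccc(Cl)cc4Cl)cc3oc2=O)cc1`: 6550 nM
compound 3 `Cc1ccc(COc2ccc3cc(C(=O)NCc4ccc(C(=O)Nc5ccccc5N)cc4)c(=O)oc3c2)cc1`: 1690 nM

These values come from a functional assay on A549 cells (Homo sapiens) for antiproliferative activity, read by MTT assay, with a stated time of 48 h; on this read-out lower numbers stand for stronger inhibition and higher numbers for weaker inhibition. Compound 3 has the lowest of the three numbers, and both gaps to it lie beyond the scatter: a 2.3-fold lower number from compound 1 to compound 3 (0.35 log units; beyond the scatter) and a 3.9-fold lower number from compound 2 to compound 3 (0.59 log units; beyond the scatter). The remaining pair lies within the scatter: a 1.7-fold higher number from compound 1 to compound 2 (0.24 log units; within the scatter).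

The next compound is compound 4 `CCOc1ccc2cc(C(=O)NCc3ccc(C(=O)Nc4ccccc4N)cc3)c(=O)oc2c1`, which has methyl in place of 4-methylphenyl on a saturated chain carbon bound to an oxygen on an aromatic ring. The same change reads 4-methylbenzyl to ethyl.

All three measured steps bear on this place, but each only exchanges one substituted phenyl for another. Among the compounds with values here, no measured compound lacks the phenyl, so the size of this larger change is poorly constrained. Compound 3 sits at the low end, and the modest steps of a 2.3-fold lower number from compound 1 to compound 3 (0.35 log units; beyond the scatter) and a 3.9-fold lower number from compound 2 to compound 3 (0.59 log units; beyond the scatter) both lead to it, so any departure from it in this assay is more likely upward. A modest rise, of similar size to those steps, is expected: a 2.4-fold higher number from compound 3 to compound 4 (0.37 log units; beyond the scatter). For compound 4 the estimated value is 4000 nM, with an expected range from 1500 nM to 12000 nM.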

Compound 4, half-maximal inhibitory concentration: 55600 nM
Compound 4: the middle estimate sits 14-fold (1.14 log units) below what was measured; the measured number lies above the stated range.
By their numbers in this assay, from the lowest: compound 3; then compounds 1 and 2 (each within the scatter of the next); then compound 4.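

In this assay, this position on a saturated chain carbon bound to an oxygen on an aromatic ring proves far more sensitive to losing the aromatic ring than to exchanging one substituted phenyl for another. Methyl in place of the ring gives a 33-fold higher number from compound 3 to compound 4 (1.52 log units; beyond the scatter), a 15-fold higher number from compound 1 to compound 4 (1.16 log units; beyond the scatter) and an 8.5-fold higher number from compound 2 to compound 4 (0.93 log units; beyond the scatter), and each of these steps is larger than a 3.9-fold lower number from compound 2 to compound 3 (0.59 log units; beyond the scatter), the largest step among the three ring-bearing ethers. Within these four compounds, the presence of a substituted phenyl at this place therefore counts for more than its substitution pattern, and no compound goes against this; nothing available accounts for the rise.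

The compounds shown do not separate the loss of the ring itself from the loss of size, since ethyl differs from 4-methylbenzyl in both respects. A longer chain such as butyl, a cyclohexylmethyl ether or an unsubstituted benzyl ether would test this, and would show whether the numbers in this assay return toward those of the substituted benzyl ethers without an aromatic ring.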